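Dropping the methoxy group from compound 1

The source may report more compounds than this note shows. Statements on the series, on what has been measured and on what is new or still open speak of the compounds shown alone.

In an ADME assay on MCF10 cells (Homo sapiens) for cytotoxicity (a higher number here means a weaker inhibitor, a lower number a stronger inhibitor), compound 1 (`CCc1nc(N)nc(N)c1C#CC(C)c1ccc(-c2ccccc2)cc1OC`) has no number to its name, only "not determined" (no result reported) as its entry, so it offers no starting value. Compound 3 (`CCc1nc(N)nc(N)c1C#CC(C)c1ccc(-c2ccccc2)cc1`) carries hydrogen in place of methoxy on an aromatic carbon. For the measured compounds named here, no measured step shows what such a change does, so no shift beyond the usual scatter is expected in this assay, in either direction. Going by the values given here, the only number to lean on comes from compound 2 (`CCc1nc(N)nc(N)c1C#CC(C)c1ccc(-c2ccc(C(=O)OC)cc2)cc1OC`), with 96000 nM as its measured value. For compound 3 the estimate is 80000 nM with 25000 nM to 250000 nM as the expected range.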

Compound 3, half-maximal inhibitory concentration: 505000 nM
For compound 3 the middle estimate is 6.3-fold (0.80 log units) below the measured one, and the stated range ends below it.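

Compound 1 has no single number to set against compound 3, so no step can be read from this pair. What swapping methoxy for hydrogen does here stays open, and no evidence shown bears on the result.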